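Catechol Diether Amides as Phosphodiesterase Inhibitors

The source may hold more compounds than are shown below. What is called first, only, known or untested is meant among the compounds shown, and "the series" means these compounds.

Compound 1 `COc1ccc(C(=O)Nc2ccccc2SC)cc1OC1CCCC1`: 1200 nM
Compound 2 `O=C(Nc1c(F)cccc1F)c1cccc(OC2CCCC2)c1`: 15000 nM

The two measured compounds were tested in an assay on isolated protein for inhibition of phosphodiesterase 4A (Sus scrofa); a lower number here means a stronger inhibitor, a higher number a weaker inhibitor. Compound 1 gives 1200 nM, the lowest number of the two, and compound 2 gives 15000 nM, a higher number that lies beyond the scatter of the measurement. Compound 1 thus stands as the stronger inhibitor of the pair on these numbers, with compound 2 as the weaker.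

Compound 3 `COc1ccc(C(=O)NN2C(Cl)=NC=CC2Cl)cc1OC1CCCC1` has not yet been measured in this assay. It keeps the core of compound 1 and differs from it in one place: a group of 8 heavy atoms (4 carbon, 2 nitrogen, 2 chlorine; one six-membered non-aromatic ring with 2 hetero atoms) in place of a group of 8 heavy atoms (7 carbon, 1 sulfur; one six-membered aromatic ring of carbon only), on an amide-type nitrogen

Among the measured compounds shown here, no step between two measured compounds bears on this change, so the expectation for compound 3 rests on compound 1 alone. Since the shared core is kept, the author expects compound 3 to land near compound 1, with a small step toward weaker inhibition a 2.1-fold higher number from compound 1 to compound 3 (0.32 log units; beyond the scatter) that may not clearly exceed the scatter. The estimated value for compound 3 is 2500 nM, with a range from 500 nM to 12000 nM.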

Compound 3, half-maximal inhibitory concentration: 400 nM
Compound 3: the middle estimate sits 6.3-fold (0.80 log units) above what was measured; measured number outside the range, below it.
By their numbers in this assay, from the lowest: compound 3; then compound 1; then compound 2.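

In this assay, the amide-type nitrogen accepted a wholesale exchange of its group: putting the chlorine-bearing six-membered non-aromatic ring with 2 hetero atoms in place of 2-(methylsulfanyl)phenyl gave a 3.0-fold lower number from compound 1 to compound 3 (0.48 log units; beyond the scatter), a modest step beyond the scatter. With the core of compound 1 kept, this shows that a six-membered aromatic ring of carbon only is not required at this place for inhibition, and that the sulfur-bearing group can be replaced with a gain rather than a loss. Nothing measured alongside this step accounts for it, so the reason for the lower number remains unknown.

The exchange alters the ring, its hetero atoms and its chlorine atoms all at once, so the compounds shown cannot assign the step to any one of these features. They also leave open how inhibition would respond to a ring carrying only one chlorine atom, or to an amine, a carboxylic acid or a longer alkyl chain on the same nitrogen.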